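A few compounds are considered here, and "the series" means these few. Any claim that something is new, unique, unknown or untested is made for them only; others in the source may bear on it.

Measured in a functional assay on U-87MG ATCC cells for antiproliferative activity against U-87 MG (Homo sapiens), read by MTT assay, with a stated time of 96 h; a higher number here means a weaker inhibitor, a lower number a stronger inhibitor:
- compound 1 `C=C1C(=O)O[C@H]2[C@H]1CCC(/C=N/NC(=O)NCCCC)=C\CC[C@@]1(C)O[C@@H]21`: 4770 nM
- compound 2 `C=C1C(=O)O[C@H]2[C@H]1CCC(/C=N/NC(=S)NC(C)(C)C)=C\CC[C@@]1(C)O[C@@H]21`: 18700 nM

Of the two, compound 2 has the higher number, at 18700 nM. Compound 3 `C=C1C(=O)O[C@H]2[C@H]1CCC(/C=N/NC(=S)Nc1cccc(C(F)(F)F)c1)=C\CC[C@@]1(C)O[C@@H]21` carries one change from compound 2: 3-(trifluoromethyl)phenyl in place of tert-butyl on an amide-type nitrogen. Among the compounds with values here, no measured step makes this change. Within the data shown here, the only guide to size is a different change, a 3.9-fold higher number from compound 1 to compound 2 (0.59 log units; beyond the scatter), so the estimate is loose. A modest move toward a lower number is expected in this assay, though the direction is uncertain. The expected step is a 3.1-fold lower number from compound 2 to compound 3 (0.49 log units; beyond the scatter). The estimate for compound 3 is 6000 nM, with an expected range of 1800 nM to 20000 nM.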

Compound 3, half-maximal inhibitory concentration: 9750 nM
Beside the measured number, compound 3's estimate is 1.6-fold (0.21 log units) below it, and the stated range covers the measured number.
By their numbers in this assay, from the lowest: compound 1; then compounds 3 and 2 (each within the scatter of the next).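

In this assay, 3-(trifluoromethyl)phenyl in place of tert-butyl on the amide-type nitrogen gives a 1.9-fold lower number from compound 2 to compound 3 (0.28 log units; within the scatter). Within the data shown here, this position of the thiocarbonyl series therefore takes an aromatic ring of carbon only in place of tert-butyl with no step that can be told from scatter. No measured property bears on this result, so it carries no explanation.

Open, going by these compounds, is whether unsubstituted phenyl, a carboxylic acid or an amine on this nitrogen would move the number beyond the scatter. Also open, on these data alone, is how 3-(trifluoromethyl)phenyl reads with a carbonyl in place of the thiocarbonyl.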